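Adding a Chloro to the Nitrophenyl Ketone: An Estimate

This account rests on a few compounds, and the source may have more. Where it says the series, first, only, none or still open, it means among the compounds named here.

Three compounds have been measured in a functional assay on DU-145 cells (Homo sapiens) for inhibition, read by trypan blue exclusion, with a stated time of 96 h; on this read-out lower numbers stand for stronger inhibition of growth and higher numbers for weaker inhibition of growth:

compound 1, `O=C(/C(=C\c1ccc([N+](=O)[O-])c(O)c1)SCc1ccc(Br)cc1)c1cc(Cl)ccc1O`: 10000 nM
compound 2, `O=C(/C(=C\c1ccc([N+](=O)[O-])c(O)c1)SCc1ccc(Br)cc1)c1c(F)c(F)c(F)c(F)c1F`: 10000 nM
compound 3, `O=C(/C(=C\c1ccc([N+](=O)[O-])c(O)c1)SCc1ccc(Br)cc1)c1ccc([N+](=O)[O-])cc1`: 1000 nM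

All three share one core and differ only in the ring attached to the carbonyl carbon. Swapping the 5-chloro-2-hydroxyphenyl of compound 1 for the 2,3,4,5,6-pentafluorophenyl of compound 2 gives no change at the digits printed from compound 1 to compound 2 (within the scatter). Moving to the 4-nitrophenyl instead gives a 10-fold lower number from compound 1 to compound 3 (1.00 log units; beyond the scatter) and a 10-fold lower number from compound 2 to compound 3 (1.00 log units; beyond the scatter). Compound 3 therefore stands lowest of the three, with each of the other two a step beyond the scatter above it.

Compound 4, `O=C(/C(=C\c1ccc([N+](=O)[O-])c(O)c1)SCc1ccc(Br)cc1)c1ccc([N+](=O)[O-])c(Cl)c1`, keeps the 4-nitrophenyl of compound 3 and adds one atom: chloro in place of hydrogen on an aromatic carbon. Going by the values given here, none of the measured steps makes a change of this kind; each exchanges the whole ring on the carbonyl carbon, so they show only that the 4-nitrophenyl itself is favourable, not what a single added chloro on it does. Among the compounds with values here, with no direct precedent, the expectation is a step of no size beyond the scatter, no change at the digits printed from compound 3 to compound 4 (within the scatter). Compound 4 is thus estimated at 1000 nM, within a range from 300 nM to 3500 nM.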

Compound 4, concentration for 50% growth inhibition: 1000 nM
Compound 4: middle estimate and measured number agree at the digits printed; low and high end bracket the measured number.
By their numbers in this assay, from the lowest: compounds 3 and 4 (each within the scatter of the next); then compounds 1 and 2 (each within the scatter of the next).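

In this assay, chloro in place of hydrogen on an aromatic carbon, ortho to the nitro group, gives no change at the digits printed from compound 3 to compound 4 (within the scatter), so this position of the 4-nitrophenyl ring accepts one added heavy atom without a step that can be read, something the earlier whole-ring exchanges could not show. The 3-chloro-4-nitrophenyl ring also stays apart from the other two rings on the carbonyl carbon, with a 10-fold lower number from compound 2 to compound 4 (1.00 log units; beyond the scatter) and a 10-fold lower number from compound 1 to compound 4 (1.00 log units; beyond the scatter), so the advantage first seen with compound 3 survives this addition. No separate measurement offers an explanation for why the chloro changes so little here.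

Going by these compounds, a single chloro says little about other groups at this position, so it remains open whether a methyl, a methoxy, an amine or a carboxylic acid in its place would also leave the number unchanged or would move it beyond the scatter. On these data alone, it also remains open whether the nitro group is itself needed on the chlorinated ring, which a nitrile in its place could test.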